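From a trifluorophenyl to a trifluoromethyl aryl group

The compounds below may be only part of what the source reports. "The series", "measured", "known", "first", "only" and "open" are said of these compounds alone.

Compound 1 `Nc1nc(NCCNc2ncc(-c3ncc[nH]3)c(-c3ccccc3Br)n2)ccc1[N+](=O)[O-]` and compound 2 `Nc1nc(NCCNc2ncc(-c3ncc[nH]3)c(-c3cc(F)c(F)cc3F)n2)ccc1[N+](=O)[O-]` share one core and differ in a single aryl group. In an ADME assay on microsomes from liver (Rattus norvegicus) for metabolic stability (on this read-out higher numbers stand for a longer-lived compound and lower numbers for a shorter-lived compound), compound 1 gives > 0.5 h as a limit of the assay, not a number. In this assay compound 2 gives > 0.5 h in the same way, so its standing is known only as a limit. Among the measured compounds shown here, the only evidence is the limit of > 0.5 h in this assay, at which 2 of the 2 values shown sit, and nothing firmer. For the measured compounds named here, the single measured change, 2,4,5-trifluorophenyl in place of 2-bromophenyl, is a step that the two limits leave unreadable from compound 1 to compound 2 and so offers no size to carry forward.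

Compound 3 `Nc1nc(NCCNc2ncc(-c3ncc[nH]3)c(-c3ccc(F)cc3C(F)(F)F)n2)ccc1[N+](=O)[O-]` departs from compound 2 by 4-fluoro-2-(trifluoromethyl)phenyl in place of 2,4,5-trifluorophenyl on an aromatic carbon and carries 4-fluoro-2-(trifluoromethyl)phenyl in place of 2,4,5-trifluorophenyl on an aromatic carbon, ortho to a 1H-imidazol-2-yl group. With no readable step behind it, no direction can be given in this assay and no change beyond the scatter is expected. The expected size is a step that the limit leaves unreadable from compound 2 to compound 3 on this estimate. For compound 3 the expected half-life is 0.7 h within an estimated range of 0.4 h to 1.5 h and the reading may again be only a limit.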

Compound 3, half-life: > 0.5 h
Compound 3 ended at the assay's limit (the forecaster's own chance of this, stated with the estimate: 75%); the middle value lies beyond the limit too.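

In this assay compound 3 gives > 0.5 h, a limit of the assay and not a number. No step among compound 1, compound 2 and compound 3 can be read, and the evidence remains: the limit of > 0.5 h in this assay, at which 3 of the 3 values shown sit.

The compounds shown leave open what the actual half-life of each compound is and whether the three aryl groups differ at all.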